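Chain-end exchange on compound 1

The source may hold more compounds than are shown below. What is called first, only, known or untested is meant among the compounds shown, and "the series" means these compounds.

Measured so far in an ADME assay on microsomes from liver (Rattus norvegicus) for metabolic stability; a higher number here means that the compound lasts longer, a lower number that the compound disappears faster
- compound 1 `CC#C[C@@H](Cc1nnn[nH]1)c1ccc(OCc2ccc3scc(-c4ccc(OCCCS(C)(=O)=O)cc4C)c3c2)cc1` gives 1.48 h
- compound 2 `CC#C[C@@H](Cc1nnn[nH]1)c1ccc(OCc2ccc3scc(C4CCCCC4)c3c2)cc1` gives 0.767 h

Within the data shown here, compound 1 holds the higher of only two numbers, but compound 2 lies within the scatter of it, so neither compound stands apart in this assay. Not yet measured is compound 3 `CC#C[C@@H](Cc1nnn[nH]1)c1ccc(OCc2ccc3scc(-c4ccc(OCCC(C)(C)O)cc4C)c3c2)cc1`, which differs from compound 1 by 1-hydroxy-1-methylethyl in place of (methylsulfonyl)methyl on a saturated chain carbon, two bonds along the chain from an oxygen on an aromatic ring. In words, 1-hydroxy-1-methylethyl stands in place of (methylsulfonyl)methyl on a saturated chain carbon, two bonds along the chain from an oxygen on an aromatic ring. The same difference reads as 3-(methylsulfonyl)propoxy to 3-hydroxy-3-methylbutoxy.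

Among the measured compounds shown here, no measured pair differs in one place, so the size of this exchange has no direct precedent. The expectation rests only on the narrow spread of the two numbers, with compound 1 at 1.48 h and compound 2 at 0.767 h. No step beyond the scatter is expected, and the direction stays uncertain. The estimated step is a 1.2-fold lower number from compound 1 to compound 3 (0.09 log units; within the scatter). For compound 3 the expected half-life is 1.2 h, with an estimated range from 0.6 h to 2.4 h.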

Compound 3, half-life: 1.03 h
For compound 3 the middle estimate is 1.2-fold (0.07 log units) above the measured one, and the stated range covers the measured number.
By their numbers in this assay, from the lowest: compounds 2, 3 and 1 (each within the scatter of the next).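

In this assay, the first step read at this place is a 1.4-fold lower number from compound 1 to compound 3 (0.16 log units; within the scatter), so replacing 3-(methylsulfonyl)propoxy with 3-hydroxy-3-methylbutoxy leaves the half-life indistinguishable from that of the parent. At this chain end, then, the sulfur-bearing (methylsulfonyl)methyl group is not required to keep the number within the scatter of compound 1, since 1-hydroxy-1-methylethyl, which has no sulfur and carries a hydrogen-bond donor, serves equally well in this one pair. Nothing available explains why the two chain ends read alike, and this single pair cannot separate a true absence of effect from a small one hidden in the scatter.

Still open, going by these compounds, is whether any group at this place can move the half-life beyond the scatter, for example a carboxylic acid, a tertiary amine, a morpholine ring or a longer chain ending in the same 1-hydroxy-1-methylethyl group. Also open is whether this exchange reads the same on a different core, as the series shown offers only this one step.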